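The compounds below may be only part of what the source reports. "The series", "measured", "known", "first", "only" and "open" are said of these compounds alone.

In a functional assay on PC-3 cells (Homo sapiens) for antiproliferative activity, read by MTT assay, with a stated time of 48 h (on this read-out higher numbers stand for weaker inhibition and lower numbers for stronger inhibition), compound 1 `CCn1c(C(=O)NCCCN(C)C)ccc1C(CC)(CC)c1ccc(OCCC(O)(CC)CC)c(C)c1` gives 2150 nM and compound 2 `CCn1c(C(=O)NCC#N)ccc1C(CC)(CC)c1ccc(OCCC(O)(CC)CC)c(C)c1` gives 17800 nM. Compound 3 `CCC(C)C(NC(=O)c1ccc(C(CC)(CC)c2ccc(OCCC(O)(CC)CC)c(C)c2)n1CC)C(=O)OC` returns only a limit, > 50000 nM, and not a number. Compound 4 `CCn1c(C(=O)NC(CC(=O)O)C(=O)OC)ccc1C(CC)(CC)c1ccc(OCCC(O)(CC)CC)c(C)c1` differs from compound 3 in one place: carboxymethyl in place of sec-butyl on a saturated chain carbon bound to an amide-type nitrogen and a carbonyl carbon. For the measured compounds named here, no measured step changes this branch on its own, so the evidence is indirect. The group on the amide-type nitrogen varies across the three measured compounds, and each change moved the number: an 8.3-fold higher number from compound 1 to compound 2 (0.92 log units; beyond the scatter) and an at least 2.8-fold higher number from compound 2 to compound 3 (0.44 log units; beyond the scatter). The largest move is an at least 23-fold higher number from compound 1 to compound 3 (1.36 log units; beyond the scatter), and compound 4 keeps most of the group found in compound 3, with only the branch exchanged. Compound 4 is therefore expected to remain close to compound 3 and far from compound 1, with no step beyond the scatter. The expected step is small, estimated as an at least 1.1-fold lower number from compound 3 to compound 4 (0.04 log units; that floor lies within the scatter). For compound 4 the estimated value is 45000 nM, with an expected range of 18000 nM to 80000 nM.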

Compound 4, half-maximal inhibitory concentration: 11200 nM
Estimate against measurement, compound 4: 4.0-fold (0.60 log units) above; measured number below the stated range.
By their numbers in this assay, from the lowest: compound 1; then compounds 4 and 2 (each within the scatter of the next). At a limit, above all of these: compound 3.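

At the saturated chain carbon bound to an amide-type nitrogen and a carbonyl carbon, carboxymethyl in place of sec-butyl keeps the count of heavy atoms yet clearly moves the read-out: an at least 4.4-fold lower number from compound 3 to compound 4 (0.64 log units; beyond the scatter). Compound 3 stands at a limit and not at a number, so this step has only a floor: the limit of > 50000 nM in this assay, at which 1 of the 4 values shown sits. The branch therefore matters in this series, but compound 4 is not separated from compound 2 (a 1.6-fold lower number from compound 2 to compound 4 (0.20 log units; within the scatter)) and remains apart from compound 1 (a 5.2-fold higher number from compound 1 to compound 4 (0.72 log units; beyond the scatter)).

This single exchange cannot show whether the gain comes from the carboxylic acid end of carboxymethyl or from the loss of sec-butyl. Going by these compounds, a longer carboxylic acid chain or an amine on this carbon could help separate the two, and its result remains open.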